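A few compounds are considered here, and "the series" means these few. Any claim that something is new, unique, unknown or untested is made for them only; others in the source may bear on it.

Working notes on the series in an ADME assay on J774.A1 cells (Mus musculus) for cytotoxicity, read by MTT assay, with a stated time of 48 h; on this read-out lower numbers stand for higher toxicity in this test and higher numbers for lower toxicity in this test. Going by the values given here, compound 2 (`CCc1ccc(-n2cc(COC(=O)c3c(C)nc4ccc(Cl)cc4c3-c3ccccc3)nn2)cc1`) is the only entry with a number (99000 nM). Compound 3 (`Cc1nc2ccc(Cl)cc2c(-c2ccccc2)c1C(=O)OCc1cn(-c2ccc(F)cc2)nn1`) has no single number on this read-out, and its entry reads ("not determined" (no result reported)). Compound 1 (`Cc1nc2ccccc2c(-c2ccccc2)c1C(=O)OCc1cn(Cc2ccccc2)nn1`) is the one further entry without a number ("not determined" (no result reported)). Compound 3 therefore cannot be ranked against compound 2.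

Compound 4 (`Cc1nc2ccc(Cl)cc2c(-c2ccccc2)c1C(=O)OCc1cn(Cc2ccccc2)nn1`) is still unmeasured and departs from compound 3 by a single change, benzyl in place of 4-fluorophenyl on an aromatic nitrogen. Among the compounds with values here, no measured pair isolates this change, so its size cannot be read from the data. In this assay, within the data shown here, no step beyond the usual scatter is expected for this change, and the only anchor is compound 2 (99000 nM). For compound 4 the half-maximal cytotoxic concentration is expected near 90000 nM with an estimated range from 40000 nM to 200000 nM on this basis.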

Compound 4, half-maximal cytotoxic concentration: 35000 nM
Beside the measured number, compound 4's estimate is 2.6-fold (0.41 log units) above it; the whole stated range lies above it.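

In this assay the group on the aromatic nitrogen now has a measured effect, with a 2.8-fold lower number from compound 2 to compound 4 (0.45 log units; beyond the scatter) on going to benzyl in place of 4-ethylphenyl. Going by these compounds alone, this is the first pair to isolate a change at this position, and it places benzyl on the side of higher toxicity in this test, though only modestly. No measurement available here explains the shift.

Steps involving compound 1 or compound 3 cannot be read, so 4-fluorophenyl remains unplaced relative to benzyl and 4-ethylphenyl. As far as these compounds go, it also remains open how a longer chain, an amine or a carboxylic acid on this nitrogen would move the number.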